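The source may hold more compounds than are shown below. What is called first, only, known or untested is meant among the compounds shown, and "the series" means these compounds.

Measured compounds:
- compound 1 `Clc1cc(Cl)cc(CO[C@H]2CCCN(Cc3ccccc3)[C@H]2c2ccccc2)c1`: > 200000 nM
- compound 2 `OC[C@@H](O[C@H]1CCCN(Cc2cccc3nonc23)[C@H]1c1ccccc1)c1cc(Cl)cc(Cl)c1`: 8000 nM

Compound 1 `Clc1cc(Cl)cc(CO[C@H]2CCCN(Cc3ccccc3)[C@H]2c2ccccc2)c1` was tested in an assay on isolated protein for activation of cGMP-dependent protein kinase 1 (Homo sapiens), read by ADP-Glo, with stated times of 120 min and 40 min (on this read-out lower numbers stand for an effect already at smaller amounts and higher numbers for an effect only at larger amounts of compound), and gives > 200000 nM, which is a limit of the assay rather than a number. Compound 1 thus stands at the limit of > 200000 nM in this assay, at which 1 of the 2 values shown sits, with no measured value of its own. Among the compounds with values here, compound 2 `OC[C@@H](O[C@H]1CCCN(Cc2cccc3nonc23)[C@H]1c1ccccc1)c1cc(Cl)cc(Cl)c1`, with a different group on the ring nitrogen and a different linker, gives 8000 nM in this assay; no single step connects it to compound 1, so the two values are only read side by side.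

Compound 3 `Clc1cc(Cl)cc(CO[C@H]2CCCN(Cc3cccnc3)[C@H]2c2ccccc2)c1` has not yet been measured. Compared with compound 1 it carries pyridin-3-yl in place of phenyl on a saturated chain carbon bound to an amine nitrogen in a ring. Within the data shown here, since compound 1 sits at a limit, there is no measured step to build on, and no step beyond the scatter is expected from so small a change. The step from compound 1 to compound 3 is expected to be a step that the limit leaves unreadable from compound 1 to compound 3. Compound 3 is therefore estimated at 300000 nM in this assay, within a range from 60000 nM to 1500000 nM.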

Compound 3, half-maximal effective concentration: 112000 nM
For compound 3 the middle estimate is 2.7-fold (0.43 log units) above the measured one; measured number inside the range.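

In this assay compound 3, with pyridin-3-yl in place of phenyl on a saturated chain carbon bound to an amine nitrogen in a ring, gives 112000 nM, a true number for this position. Compound 1 has only a limit of the assay, > 200000 nM. The change can therefore be read only as an at least 1.7-fold lower number from compound 1 to compound 3 (0.25 log units; that floor lies within the scatter), so the data show neither a change beyond the scatter nor the real size of the step, and the one reading remains tied to that limit: the limit of > 200000 nM in this assay, at which 1 of the 3 values shown sits.

Going by these compounds, it remains open whether the nitrogen's place within the ring matters, as pyridin-2-yl or pyridin-4-yl at this position could show. On these data alone, it is also open whether a ring with a second nitrogen, such as pyrimidin-5-yl, would shift the value at all.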